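The source may report more compounds than this note shows. Statements on the series, on what has been measured and on what is new or still open speak of the compounds shown alone.

For the measured compounds named here, compound 2 `O=[N+]([O-])c1ccc2c(c1)CCN2S(=O)(=O)c1ccc(-c2cnc(C3CC3)o2)cc1` gives 73.1% in a functional assay on A549 cells (Homo sapiens) for inhibition, read by MTT assay, tested at 10 uM (a lower number here means less inhibition, a higher number more inhibition at the concentration tested (going by the name of the read-out)), the higher of the two numbers measured so far, while compound 1 `CS(=O)(=O)c1ccc2c(c1)CCN2S(=O)(=O)c1ccc(-c2cnc(C3CC3)o2)cc1` gives 4.14% in this assay. The step of a number 69 percentage points higher from compound 1 to compound 2 (beyond the scatter) is large and beyond the scatter. Compound 3 `N#Cc1ccc2c(c1)CCN2S(=O)(=O)c1ccc(-c2cnc(C3CC3)o2)cc1` differs from compound 2 by cyano in place of nitro on an aromatic carbon. Going by the values given here, the one measured step shows that exchanging the group at this position can move the read-out far, but no cyano compound has been tested, so the direction for compound 3 remains open. Compound 3 is expected to give 45%, in a range from 15% to 80%. That estimate means a step of a number 28.1 percentage points lower from compound 2 to compound 3 (beyond the scatter).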

Compound 3, a percentage reported as inhibition, at one concentration (the size of the read-out at that concentration, not a potency): 28.4%
For compound 3 the middle estimate is 16.6 percentage points above the measured one; measured number inside the range.
By their numbers in this assay, from the lowest: compound 1; then compound 3; then compound 2.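

Cyano in place of nitro gives a number 44.7 percentage points lower from compound 2 to compound 3 (beyond the scatter) in this assay and, against the methylsulfonyl compound, cyano in place of methylsulfonyl gives a number 24.3 percentage points higher from compound 1 to compound 3 (beyond the scatter) in the same read-out. This aromatic carbon therefore separates three groups into three distinct levels, with cyano in the middle, rather than only the two extremes seen before. Nothing available explains this order. From the compounds shown here alone, whether an amine or a carboxylic acid here would read above or below these three remains open, as does whether the order holds on a different core.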